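Phenyl for 4-methylbenzyl on the amide nitrogen

A few compounds are considered here, and "the series" means these few. Any claim that something is new, unique, unknown or untested is made for them only; others in the source may bear on it.

Working notes on three measured compounds in a functional assay on HeLa cells (Homo sapiens) for cytotoxicity, read by MTT assay, with a stated time of 48 h (on this read-out lower numbers stand for stronger inhibition and higher numbers for weaker inhibition), and one still to be read. Compound 1 (`COc1cc([C@@H]2C[C@@]2(CO)C(=O)Nc2ccccc2)cc(OC)c1OC`) gives 86400 nM and compound 3 (`COc1cc([C@H]2C[C@]2(CO)C(=O)NCc2ccc(C)cc2)cc(OC)c1OC`) gives 57800 nM in this test. These two values lie within the scatter of each other, so compound 3 cannot be separated from compound 1 on these numbers.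

Compound 2 (`CCOC(=O)[C@]1(C(=O)Nc2ccccc2)C[C@@H]1c1cc(OC)c(OC)c(OC)c1`) returns only a limit of the assay (> 100000 nM).

Compound 4 (`COc1cc([C@H]2C[C@]2(CO)C(=O)Nc2ccccc2)cc(OC)c1OC`) is the next to be considered. It has phenyl in place of 4-methylbenzyl on an amide-type nitrogen.

Among the compounds with values here, no measured pair differs in one place only, so there is no direct precedent for the size of this step in this assay on which to draw. The nearest guide is compound 1, which also carries phenyl on an amide-type nitrogen and gives 86400 nM in the same test. On that basis no step beyond the scatter is expected, and no direction is favoured with confidence. The estimated step is small (a 1.2-fold higher number from compound 3 to compound 4 (0.08 log units; within the scatter)) and stays inside the scatter. In this assay the expected value for compound 4 is 70000 nM (estimated range 30000 nM to 100000 nM).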

Compound 4, half-maximal inhibitory concentration: > 100000 nM
Compound 4: a limit, no number; the forecaster's own chance of this, stated with the estimate: 25%; middle value at least 1.4-fold (0.15 log units) away from the limit.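

Within the data shown here, replacing 4-methylbenzyl with phenyl on the amide-type nitrogen gives the first direct step at this position in this assay, an at least 1.7-fold higher number from compound 3 to compound 4 (0.23 log units; that floor lies within the scatter); compound 4 returns a limit of the assay rather than a number, so only a floor can be read and no change is established. The comparison with compound 1 isolates configuration, but an at least 1.1-fold higher number from compound 1 to compound 4 (0.06 log units; that floor lies within the scatter) is again only a floor, so no effect of configuration is established, and the pair's value as a test rests on one fact: the fact that compounds 1 and 4 differ only in the configuration as drawn The step from compound 2 to compound 4 cannot be read, and the top of the test now constrains the series: the limit of > 100000 nM in this assay, at which 2 of the 4 values shown sit.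

As far as these compounds go, it remains open whether the mirror image of compound 3 would give a value near that of compound 3, and whether the difference between these amide groups can be resolved at all. Plain benzyl or a longer chain such as 2-phenylethyl on the amide nitrogen, or an amine or a carboxylic acid on the aromatic ring of that group, could show whether any value falls clear of both the scatter and the limit.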